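From an Open Chain to a Ring on the Sulfonamide

This account rests on a few compounds, and the source may have more. Where it says the series, first, only, none or still open, it means among the compounds named here.

Measured compounds:
compound 1, `CC(O)(C(=O)Nc1ccc(S(=O)(=O)N2CCNCC2)cc1)C(F)(F)F`
compound 2, `CCCN(CCC)S(=O)(=O)c1ccc(NC(=O)C(C)(O)C(F)(F)F)cc1`

In an assay on a protein complex (Cavia porcellus) with sulfonylurea receptors; K-ATP channels (Homo sapiens) as the target (on this read-out lower numbers stand for stronger inhibition and higher numbers for weaker inhibition), compound 1 gives > 30000 nM, which is a limit of the assay (the limit of > 30000 nM in this assay, at which 1 of the 2 values shown sits). In this assay compound 2 gives 6440 nM, the only number shown. Going by the values given here, the one measured step at this position is an at least 4.6-fold lower number from compound 1 to compound 2 (0.66 log units; beyond the scatter). Compound 3, `CC(O)(C(=O)Nc1ccc(S(=O)(=O)N2CCCCC2)cc1)C(F)(F)F`, differs from compound 2 in one place: piperidin-1-yl in place of dipropylamino on a sulfonyl sulfur. Since piperidin-1-yl keeps the zero hydrogen-bond donors and acceptors of dipropylamino, only a small change is expected here. Compound 3 is expected at 7000 nM (2000 nM to 30000 nM) in this assay. The expected step of a 1.1-fold higher number from compound 2 to compound 3 (0.04 log units; within the scatter) lies within the scatter.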

Compound 3, half-maximal inhibitory concentration: 9250 nM
The estimate for compound 3 lay 1.3-fold (0.12 log units) below the measured number, within the range that was stated.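

On the sulfonyl sulfur, piperidin-1-yl and dipropylamino cannot be told apart in this assay: the step is a 1.4-fold higher number from compound 2 to compound 3 (0.16 log units; within the scatter). A ring as such is therefore not what separates compound 1 from the others, since swapping piperazin-1-yl for piperidin-1-yl gives an at least 3.2-fold lower number from compound 1 to compound 3 (0.51 log units; beyond the scatter). The value of compound 1 is a limit of the assay, not a number: the limit of > 30000 nM in this assay, at which 1 of the 3 values shown sits.

On these data alone, what remains open is whether other six-membered rings on the sulfur, such as morpholin-4-yl or 4-methylpiperazin-1-yl, would read like compound 3 or like compound 1. Smaller rings, such as pyrrolidin-1-yl, also remain open.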